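tert-Butyl in place of methyl on the core of the analogue with the lowest number

A few compounds are considered here, and "the series" means these few. Any claim that something is new, unique, unknown or untested is made for them only; others in the source may bear on it.

Measured compounds:
compound 1 `CCN1CCc2c(c(C)nn2C(=O)Nc2ccc(C)cc2C)C1` — 56.1%
compound 2 `CCN1CCc2c(c(C)nn2C(=O)Nc2cc(C)ccc2F)C1` — 10.5%
compound 3 `CCN1CCc2c(c(C)nn2C(=O)Nc2ccc(Cl)cc2)C1` — 55.2%

Three ureas sharing one core were tested in a functional assay on the whole organism (strain Swiss albino) for inhibition, with Mus musculus as the target, in the writhing test, with a stated time of 30 min, at a dose of 100 mg/kg; on this read-out higher numbers stand for more inhibition at the one dose given (going by the name of the read-out) and lower numbers for less inhibition. Compound 1 gives 56.1% and compound 3 gives 55.2%, two numbers that lie within the scatter of each other. Compound 2 stands lowest of the three with 10.5%, and both other compounds lie beyond the scatter above it.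

Compound 4 `CCN1CCc2c(c(C(C)(C)C)nn2C(=O)Nc2cc(C)ccc2F)C1` has not yet been measured. It differs from compound 2 in one place: tert-butyl in place of methyl on an aromatic carbon. Among the compounds with values here, the measured set contains no pair that isolates this kind of change, so nothing in the data shows its size or direction; the only anchor is the value of compound 2. The expectation is therefore a small step, most likely upward but possibly none beyond the scatter, and the expected size of the step is a number 9.5 percentage points higher from compound 2 to compound 4 (within the scatter). Compound 4 is estimated at 20%, within a range from 5% to 45% in this assay.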

Compound 4, a percentage reported as inhibition, in the whole organism at one dose (the size of the read-out at that dose, not a potency): 17.5%
Beside the measured number, compound 4's estimate is 2.5 percentage points above it; the measured number falls inside the stated range.
By their numbers in this assay, from the lowest: compounds 2 and 4 (each within the scatter of the next); then compounds 3 and 1 (each within the scatter of the next).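

In this assay, tert-butyl in place of methyl on an aromatic carbon of the shared core gives a number 7 percentage points higher from compound 2 to compound 4 (within the scatter). All three earlier compounds carry methyl at this carbon, so they could not show whether the position accepts a different group; this pair shows that, with the rest of compound 2 held fixed, going from 1 heavy atom to 4 leaves the read-out within the usual scatter. Nothing shown here accounts for this outcome.

One pair leaves open whether tert-butyl in place of methyl would give a similar step with the aryl groups of compound 1 or compound 3, whose numbers stand much higher. Also open, on these data alone, is how this carbon would respond to a group of another kind, such as an amine, a carboxylic acid or a longer chain.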